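This account rests on a few compounds, and the source may have more. Where it says the series, first, only, none or still open, it means among the compounds named here.

Three compounds share one core, and all were tested in a functional assay on CHO cells for antagonist activity at prostaglandin E2 receptor EP1 subtype (Homo sapiens), read by FLIPR and calcium flux; a lower number here means a stronger inhibitor, a higher number a weaker inhibitor. Compound 1 `COc1ccc(Cc2nnc(CN(c3cccc(Cl)c3Cl)S(=O)(=O)c3ccc(C)cc3)o2)cc1` gives 39.8 nM in this assay. Compound 2 `CCOc1ccc(Cc2nnc(CN(c3cccc(Cl)c3Cl)S(=O)(=O)c3ccc(C)cc3)o2)cc1` gives 31.6 nM. Compound 3 `COc1ccc(Nc2nnc(CN(c3cccc(Cl)c3C)S(=O)(=O)c3ccc(C)cc3)o2)cc1` gives 79.4 nM, the highest of the three numbers; its gap to compound 1 is within the scatter, while its gap to compound 2 lies beyond it.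

Going by the values given here, the one measured single-point step, a 1.3-fold lower number from compound 1 to compound 2 (0.10 log units; within the scatter), concerns a methyl in place of a hydrogen on a saturated chain carbon bound to an oxygen on an aromatic ring. It does not touch the change now in question.

Compound 4 `COc1ccc(Nc2nnc(CN(c3cccc(Cl)c3Cl)S(=O)(=O)c3ccc(C)cc3)o2)cc1` differs from compound 3 in one place: chloro in place of methyl on an aromatic carbon. Among the compounds with values here, no measured pair isolates this swap. Compound 1 carries the same 2,3-dichlorophenyl as compound 4 but also a different link to the core, so compound 1 and compound 3 differ in two places and only their two values can be compared: compound 1 sits at 39.8 nM and compound 3 at 79.4 nM, a gap within the scatter.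

Within the data shown here, with no direct precedent, compound 4 is expected to land close to compound 3, with the step of a 1.4-fold lower number from compound 3 to compound 4 (0.15 log units; within the scatter) estimated to stay within the scatter. The estimate for compound 4 in this assay is 56 nM, with a range from 22 nM to 140 nM.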

Compound 4, inhibition constant: 50.1 nM
Compound 4: middle estimate off by 1.1-fold (0.05 log units), on the high side; the range from low to high includes it.
By their numbers in this assay, from the lowest: compounds 2, 1, 4 and 3 (each within the scatter of the next, the first and the last beyond it).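

In this assay, the first direct test of chloro in place of methyl on this aromatic carbon, ortho to a chloro group, gives a 1.6-fold lower number from compound 3 to compound 4 (0.20 log units; within the scatter), so going from 3-chloro-2-methylphenyl to 2,3-dichlorophenyl produces no difference that can be told apart from repeat variation. Going by these compounds alone, compound 4 also gives the first one-place comparisons of the group on the other side of the shared core: (4-methoxyphenyl)amino in place of 4-methoxybenzyl gives a 1.3-fold higher number from compound 1 to compound 4 (0.10 log units; within the scatter), and (4-methoxyphenyl)amino in place of 4-ethoxybenzyl gives a 1.6-fold higher number from compound 2 to compound 4 (0.20 log units; within the scatter), so neither comparison separates the amino-linked group from the benzyl groups. Nothing available bears on the reason for these results.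

The compounds shown carry only methyl or chloro at this aromatic carbon, so how a methoxy, a trifluoromethyl or a nitrile there would read remains open. On these data alone, it is also open whether chloro and methyl would still read alike with a benzyl group in place of the (4-methoxyphenyl)amino group, and whether an ether link or a longer chain at that point on the core would stay in the same range.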